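The source may hold more compounds than are shown below. What is called first, only, known or untested is meant among the compounds shown, and "the series" means these compounds.

In a functional assay (strain AB) with Danio rerio as the target, read by microscopy, with a stated time of 1 h (on this read-out lower numbers stand for an effect already at smaller amounts and higher numbers for an effect only at larger amounts of compound), three compounds sharing one core have been measured so far. Compound 1 `CCN1CCc2c(sc(NC(=O)Nc3ccc(Cl)cc3)c2C(N)=O)C1` gives 3120 nM while compound 2 `CC(C)(C)CN1CCc2c(sc(NC(=O)Nc3ccc(Cl)cc3)c2C(N)=O)C1` gives 5560 nM and compound 3 `CC(C)(C)OC(=O)CCN1CCc2c(sc(NC(=O)Nc3ccc(Cl)cc3)c2C(N)=O)C1` gives 1100 nM as the lowest of the three numbers. Compound 3 lies beyond the scatter from both of the others.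

The next compound is compound 4 `CC(C)N1CCc2c(sc(NC(=O)Nc3ccc(Cl)cc3)c2C(N)=O)C1` and it differs from compound 3 in one place, with isopropyl in place of 2-(tert-butoxycarbonyl)ethyl on an amine nitrogen in a ring and the shared core unchanged.

Among the measured compounds shown here, three measured steps bear on this change. Between the two compounds without tert-butoxycarbonyl the data show a 1.8-fold higher number from compound 1 to compound 2 (0.25 log units; within the scatter) as the only difference. Adding tert-butoxycarbonyl gave a 2.8-fold lower number from compound 1 to compound 3 (0.45 log units; beyond the scatter) as a modest step, and the exchange of tert-butyl for (tert-butoxycarbonyl)methyl gave a 5.1-fold lower number from compound 2 to compound 3 (0.70 log units; beyond the scatter) as another modest step.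

Compound 4 gives up the tert-butoxycarbonyl group, so its number is expected to lie near those of compound 1 at 3120 nM and compound 2 at 5560 nM rather than near the lowest one. The expected change in this assay is therefore a 3.2-fold higher number from compound 3 to compound 4 (0.50 log units; beyond the scatter) as an estimated modest step toward a higher number. Compound 4 is estimated at 3500 nM with 1600 nM to 7500 nM as its expected range.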

Compound 4, half-maximal effective concentration: 1490 nM
For compound 4 the middle estimate is 2.3-fold (0.37 log units) above the measured one, outside the stated range (below it).
By their numbers in this assay, from the lowest: compounds 3 and 4 (each within the scatter of the next); then compounds 1 and 2 (each within the scatter of the next).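

In this assay, replacing 2-(tert-butoxycarbonyl)ethyl with isopropyl on the amine nitrogen in a ring gives a 1.4-fold higher number from compound 3 to compound 4 (0.13 log units; within the scatter) and so leaves the number within the scatter, which shows that the tert-butoxycarbonyl group is not needed at this position to reach this range of numbers. The three compounds carrying only carbon groups on this nitrogen also separate from one another, with a 3.7-fold lower number from compound 2 to compound 4 (0.57 log units; beyond the scatter) for isopropyl in place of neopentyl and a 2.1-fold lower number from compound 1 to compound 4 (0.32 log units; beyond the scatter) for methyl in place of hydrogen on the saturated chain carbon bound to that nitrogen, so a small change in the carbon group here moves the number beyond the scatter. Nothing given here accounts for these steps.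

The compounds shown leave open how a free carboxylic acid in place of the tert-butoxycarbonyl group, or a primary amine at the end of a longer chain, would read at this nitrogen. They also leave open whether a cyclopropyl or tert-butyl group bound directly to the same nitrogen would stay with compound 4 or move towards compound 2.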